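The compounds below may be only part of what the source reports. "The series", "measured", "known", "first", "only" and "open" are said of these compounds alone.

For the measured compounds named here, in a functional assay on MKN-74 cells (Homo sapiens) for antiproliferative activity, with a stated time of 24 h (on this read-out higher numbers stand for weaker inhibition and lower numbers for stronger inhibition), compound 2 `Cc1ccc(C(=O)Nc2sc3c(c2C(N)=O)CCN(Cc2ccc(Cl)cc2Cl)C3)cc1` gives 25500 nM, the highest of the three numbers measured so far. Compound 1 `NC(=O)c1c(NC(=O)c2ccc(C(F)(F)F)cc2)sc2c1CCN(Cc1ccc(Cl)cc1Cl)C2` gives 10900 nM and compound 3 `NC(=O)c1c(NC(=O)c2ccccc2F)sc2c1CCN(Cc1ccc(Cl)cc1Cl)C2` gives 9610 nM; the steps of a 2.3-fold higher number from compound 1 to compound 2 (0.37 log units; beyond the scatter) and a 2.7-fold lower number from compound 2 to compound 3 (0.42 log units; beyond the scatter) are both modest. Compound 4 `Cc1ccc(C(=O)Nc2sc3c(c2C(N)=O)CCN(C(=O)Nc2ccccc2Cl)C3)cc1` differs from compound 2 in a different place: (2-chlorophenyl)carbamoyl in place of 2,4-dichlorobenzyl on an amine nitrogen in a ring. Going by the values given here, none of the measured steps touches this ring nitrogen, so no step bears on the change directly; the changes on the amide side moved the numbers only modestly, and the whole set stays weak. Compound 4 is therefore expected to remain in the same weak region, with a step of a 1.3-fold lower number from compound 2 to compound 4 (0.11 log units; within the scatter) and wide uncertainty. The estimate for compound 4 is 20000 nM, from 5000 nM to 80000 nM.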

Compound 4, half-maximal inhibitory concentration: 27600 nM
Beside the measured number, compound 4's estimate is 1.4-fold (0.14 log units) below it; the measured number falls inside the stated range.
By their numbers in this assay, from the lowest: compounds 3 and 1 (each within the scatter of the next); then compounds 2 and 4 (each within the scatter of the next).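

The earlier steps shown here all changed the amide side, while this one changes the amine nitrogen in the ring: (2-chlorophenyl)carbamoyl in place of 2,4-dichlorobenzyl gives a 1.1-fold higher number from compound 2 to compound 4 (0.03 log units; within the scatter). For this pair, the exchange adds a hydrogen-bond donor and acceptor, yet the number stays within the scatter. Nothing available explains this outcome. As far as these compounds go, it remains open whether a smaller group on this nitrogen, such as acetyl, or a carboxylic acid would shift the number beyond the scatter. Also open, from the compounds shown here alone, is whether (2-chlorophenyl)carbamoyl would behave alike with the 2-fluorophenyl amide of compound 3.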